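The compounds below may be only part of what the source reports. "The series", "measured", "known", "first", "only" and "open" are said of these compounds alone.

In an assay on isolated protein for inhibition of thiosulfate sulfurtransferase (Homo sapiens), with a stated time of 60 min, in the absence of a further agent (on this read-out higher numbers stand for weaker inhibition and lower numbers for stronger inhibition), compound 1 `O=C(Nc1ccc(Sc2nc3ccccc3s2)c(Cl)c1)c1cccc(Br)c1O` gives > 100000 nM, which is a limit of the assay rather than a number. Its measured neighbour, compound 2 `O=C(Nc1ccc(Sc2nc3ccccc3s2)cc1)c1cccc(Br)c1O`, has hydrogen in place of chloro on an aromatic carbon. In this assay compound 2 gives > 100000 nM, again a limit and not a number. The step that the two limits leave unreadable from compound 1 to compound 2 therefore cannot be sized. Among the measured compounds shown here, the only evidence is the limit of > 100000 nM in this assay, at which 2 of the 2 values shown sit, so compound 1 stands at that limit with nothing to rank it against.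

Compound 3 `O=C(Nc1ccc(Sc2nc3ccccc3s2)c(Cl)c1)c1ccccc1` has not been measured. It differs from compound 1 in one place: phenyl in place of 3-bromo-2-hydroxyphenyl on a carbonyl carbon. No measured step bears on this change, and the one step shown is unreadable. With both measured compounds at the limit, no direction can be read and no step beyond the scatter is expected. Compound 3 is therefore expected to give 100000 nM, with a range from 30000 nM to 300000 nM, most likely again as a limit rather than a number. The step of a number no higher from compound 1 to compound 3 (the limit leaves the size open) is estimated to be flat.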

Compound 3, half-maximal inhibitory concentration: > 100000 nM
Compound 3 was reported as a limit; the forecaster's own chance of this, stated with the estimate: 85%; the middle value sits exactly at the limit.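

No new step can be read between compound 1 and compound 3, since neither gives a number: the limit of > 100000 nM in this assay, at which 3 of the 3 values shown sit.

The compounds shown leave open which change to the shared core, if any, would bring a value inside the measurable range of this assay.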